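The source may report more compounds than this note shows. Statements on the series, on what has been measured and on what is new or still open speak of the compounds shown alone.

Measured so far:
compound 1 `O=C(NO)c1ccc(CNC(=O)c2n[nH]cc2NC(=O)c2ccccc2Cl)cc1`: 6170 nM
compound 2 `Nc1ccccc1NC(=O)c1ccc(CNC(=O)c2n[nH]cc2NC(=O)c2ccccc2Cl)cc1`: 6360 nM

In a functional assay on NCI-H460 cells (Homo sapiens) for inhibition, read by CCK-8 assay, with a stated time of 72 h (a lower number here means a stronger inhibitor, a higher number a weaker inhibitor), compound 2 gives 6360 nM, and compound 1 gives 6170 nM. Among the compounds with values here, the only measured step, a 1.0-fold higher number from compound 1 to compound 2 (0.01 log units; within the scatter), leaves the two within the scatter of each other, so compound 2 stands level with compound 1. Compound 3 `Nc1ccccc1NC(=O)c1ccc(CNC(=O)c2n[nH]cc2NC(=O)c2c(Cl)cccc2Cl)cc1` differs from compound 2 by chloro in place of hydrogen on an aromatic carbon. The measured step touches a different part of the molecule and gives no guidance on the ((2-chlorophenyl)carbonyl)amino portion. With nothing pointing either way, the expected step is a 1.0-fold higher number from compound 2 to compound 3 (0.00 log units; within the scatter), none beyond the scatter. Compound 3 is therefore estimated at 6400 nM, range 2500 nM to 16000 nM.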

Compound 3, half-maximal inhibitory concentration: 4190 nM
Estimate against measurement, compound 3: 1.5-fold (0.18 log units) above, and the stated range covers the measured number.
By their numbers in this assay, from the lowest: compounds 3, 1 and 2 (each within the scatter of the next).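

In this assay, the change from 2-chlorophenyl to 2,6-dichlorophenyl gives a 1.5-fold lower number from compound 2 to compound 3 (0.18 log units; within the scatter), so adding a further chloro on this ring leaves the number within the scatter. Within the data shown here, this is the first reading on the ((2-chlorophenyl)carbonyl)amino portion, as the earlier step concerned only the group on the amide-type nitrogen. No measurement available bears on this result.

Open, as far as these compounds go, is whether a methoxy group or an amine at this place, or a phenyl without chloro, would give a step beyond the scatter. Also open, from the compounds shown here alone, is how the 2,6-dichlorophenyl group reads with hydroxy on the amide-type nitrogen.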